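Propyl for isopropyl on the aryl ether of compound 1

This account rests on a few compounds, and the source may have more. Where it says the series, first, only, none or still open, it means among the compounds named here.

Three coumarin-type compounds sharing one core have been measured in an assay on V79MZh11B2 cells for inhibition of cytochrome P450 11B2, mitochondrial (Homo sapiens), read by HPLC, with a stated time of 25 min; a higher number here means a weaker inhibitor, a lower number a stronger inhibitor. Compound 1 `CC(C)Oc1ccc(COc2ccc3c(Cn4ccnc4)cc(=O)oc3c2)cc1` gives 82 nM in this assay. Compound 2 `COc1cccc(COc2ccc3c(Cn4ccnc4)cc(=O)oc3c2)c1` gives 127 nM, and compound 3 `O=c1cc(Cn2ccnc2)c2ccc(OCc3cc(F)cc(F)c3)cc2o1` gives 200 nM. For the measured compounds named here, no measured compound gives a lower number than compound 1, though its gap to compound 2 lies within the scatter of repeated measurements, while its gap to compound 3 lies beyond it. Going by the values given here, the single measured step, a 1.6-fold higher number from compound 2 to compound 3 (0.20 log units; within the scatter), concerns the aryl group on the ether chain and stays within the scatter.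

Compound 4 `CCCOc1ccc(COc2ccc3c(Cn4ccnc4)cc(=O)oc3c2)cc1` has not yet been measured. It differs from compound 1 in one place: propyl in place of isopropyl on an oxygen on an aromatic ring. The same atoms are present and only the branching of the three-carbon chain on the aromatic oxygen changes. Among the compounds with values here, no measured step alters this chain, so the measured data give no direct guide; the one available step, from a different part of the molecule, was within the scatter. A step in this assay of no more than the scatter is therefore expected, in no particular direction. Compound 4 is estimated at 90 nM, with a range from 45 nM to 180 nM, corresponding to an expected 1.1-fold higher number from compound 1 to compound 4 (0.04 log units; within the scatter).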

Compound 4, half-maximal inhibitory concentration: 77 nM
Beside the measured number, compound 4's estimate is 1.2-fold (0.07 log units) above it; the range from low to high includes it.
By their numbers in this assay, from the lowest: compounds 4, 1, 2 and 3 (each within the scatter of the next, the first and the last beyond it).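

In this assay, for the compounds shown here, the change of propyl in place of isopropyl on an oxygen on an aromatic ring gives a 1.1-fold lower number from compound 1 to compound 4 (0.03 log units; within the scatter), and this is the first measured step at this chain rather than on the aryl group of the ether chain. The two chains hold the same atoms, joined differently, so this pair shows that the branched and the straight form can be exchanged at this place without a step beyond the scatter, and neither form can be ranked above the other from these numbers. Nothing available explains this result or says how the chain is accommodated.

The compounds shown test only this one exchange at this place, so they cannot say how far the tolerance extends, or whether a longer chain such as butyl or hexyl, a cyclopentyl ring, or a chain ending in an amine or a carboxylic acid would also stay within the scatter of the isopropyl compound. As far as these compounds go, whether the same exchange would give a similarly small step on another aryl group of the ether chain also remains open.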